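This account rests on a few compounds, and the source may have more. Where it says the series, first, only, none or still open, it means among the compounds named here.

Measured compounds:
compound 1 `Fc1ccc(C(OCCC2CCN(Cc3ccc(Br)cc3)CC2)c2ccc(F)cc2)cc1`, in an assay on isolated protein for binding affinity to sodium-dependent dopamine transporter (Rattus norvegicus) (on this read-out lower numbers stand for stronger inhibition and higher numbers for weaker inhibition), compound 1 gives 1.1 nM
compound 2 `Fc1ccc(C(OCCC2CCN(Cc3cccc4ccccc34)CC2)c2ccc(F)cc2)cc1`, in this assay compound 2 gives 16 nM
compound 3 `Fc1ccc(C(OCCC2CCN(Cc3ccc(Cl)cc3)CC2)c2ccc(F)cc2)cc1`, in this assay compound 3 gives 1.2 nM

Compound 3 stands second highest of the three numbers in this assay. Its nearest neighbour is compound 1, separated by a 1.1-fold higher number from compound 1 to compound 3 (0.04 log units; within the scatter), a difference within the scatter. Its furthest neighbour is compound 2, separated by a 13-fold lower number from compound 2 to compound 3 (1.12 log units; beyond the scatter), a large step beyond the scatter.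

The next compound, compound 4 `Cc1ccc(CN2CCC(CCOC(c3ccc(F)cc3)c3ccc(F)cc3)CC2)cc1`, differs from compound 3 only in one spot: methyl in place of chloro on an aromatic carbon. In the wider reading this is 4-chlorobenzyl to 4-methylbenzyl.

Within the data shown here, none of the measured steps shows methyl in place of chloro. The step from compound 1 to compound 3, a 1.1-fold higher number from compound 1 to compound 3 (0.04 log units; within the scatter), shows that exchanging bromo for chloro on this aromatic carbon left the number within the scatter, so a single-atom exchange at this place has so far been tolerated. The large steps of a 15-fold higher number from compound 1 to compound 2 (1.16 log units; beyond the scatter) and a 13-fold lower number from compound 2 to compound 3 (1.12 log units; beyond the scatter) concern a different change, naphthalen-1-yl against a para-substituted phenyl, and do not bear directly on the chloro to methyl exchange.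

On this basis compound 4 is expected to give a number near that of compound 3, with a step of a 1.7-fold higher number from compound 3 to compound 4 (0.22 log units; within the scatter) that may lie within the scatter. The estimate for compound 4 in this assay is 2 nM, within a range from 0.8 nM to 6 nM.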

Compound 4, inhibition constant: 5.7 nM
Compound 4: the middle estimate sits 2.9-fold (0.45 log units) below what was measured; low and high end bracket the measured number.
By their numbers in this assay, from the lowest: compounds 1 and 3 (each within the scatter of the next); then compound 4; then compound 2.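

In this assay, methyl in place of chloro on this aromatic carbon moves the number beyond the scatter (a 4.8-fold higher number from compound 3 to compound 4 (0.68 log units; beyond the scatter)), and methyl in place of bromo does the same (a 5.2-fold higher number from compound 1 to compound 4 (0.71 log units; beyond the scatter)), whereas chloro in place of bromo stayed within the scatter (a 1.1-fold higher number from compound 1 to compound 3 (0.04 log units; within the scatter)); the place therefore does not accept every exchange of one heavy atom for another, and among these three groups methyl stands apart from the two halogens. The 4-methylphenyl group of compound 4 still gives a lower number than the naphthalen-1-yl group of compound 2 (a 2.8-fold lower number from compound 2 to compound 4 (0.45 log units; beyond the scatter)), so on the shared core compound 4 lies between the two halogen compounds and compound 2. Nothing shown here explains why methyl differs from chloro and bromo at this place.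

On these data alone, with only chloro, bromo and methyl compared at this place, it remains open where fluoro, methoxy, trifluoromethyl or an amine would fall on this scale. Also open, as far as these compounds go, is whether methyl in place of chloro would give a step of this size on a core other than that of compound 3.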